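Trimming the Sulfonamide Arm of Compound 3

A few compounds are considered here, and "the series" means these few. Any claim that something is new, unique, unknown or untested is made for them only; others in the source may bear on it.

Three compounds share a core carrying a triazole. Compound 1 `COc1ccc(-c2cn(C/C=C3\OC(=O)C(OCc4ccccc4)=C3OCc3ccccc3)nn2)cc1` gives 39100 nM in a functional assay on MCF7 cells (Homo sapiens) for antiproliferative activity, read by MTT assay, with a stated time of 72 h; a lower number here means a stronger inhibitor, a higher number a weaker inhibitor. Compound 2 `Cc1ccc(S(=O)(=O)NCc2cn(C[C@H](O)[C@H]3OC(=O)C(OCc4ccccc4)=C3OCc3ccccc3)nn2)cc1` gives 6400 nM, and compound 3 `O=C1O[C@H]([C@@H](O)Cn2cc(CNS(=O)(=O)c3ccc(Cl)cc3F)nn2)C(OCc2ccccc2)=C1OCc1ccccc1` gives 3390 nM, the lowest of the three numbers; the step of a 1.9-fold lower number from compound 2 to compound 3 (0.28 log units; within the scatter) lies within the scatter. Compound 4 `O=C1O[C@H]([C@@H](O)Cn2cc(CCO)nn2)C(OCc2ccccc2)=C1OCc1ccccc1` differs from compound 3 by hydroxymethyl in place of ((4-chloro-2-fluorophenyl)sulfonyl)amino on a saturated chain carbon bound to an aromatic carbon. Among the measured compounds shown here, no measured step removes this whole group: the only single-place step exchanged one ring for another on the sulfonyl sulfur, so the size of this change is untested. Compound 1, which lacks a sulfonamide, sits far higher. Compound 4 is therefore expected to show a weaker result, estimated at 15000 nM within 4000 nM to 50000 nM, a step of a 4.4-fold higher number from compound 3 to compound 4 (0.65 log units; beyond the scatter).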

Compound 4, half-maximal inhibitory concentration: 63400 nM
The estimate for compound 4 lay 4.2-fold (0.63 log units) below the measured number; the whole stated range lies below it.
By their numbers in this assay, from the lowest: compounds 3 and 2 (each within the scatter of the next); then compounds 1 and 4 (each within the scatter of the next).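

The earlier compounds shown here only exchanged one ring for another on the sulfonyl sulfur, whereas here the whole arm is removed. In this assay, hydroxymethyl in place of the arm brings a 19-fold higher number from compound 3 to compound 4 (1.27 log units; beyond the scatter), and the same change from the 4-methylphenyl arm brings a 9.9-fold higher number from compound 2 to compound 4 (1.00 log units; beyond the scatter), so on this saturated chain carbon the arm as a whole counts for much more than the ring exchange did. No measurement here accounts for this loss. Which part of the arm matters, the ring, the sulfonyl or the nitrogen, remains open. An amine or an amide carrying the same ring in this place would help separate them.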